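The source may hold more compounds than are shown below. What is called first, only, known or untested is meant among the compounds shown, and "the series" means these compounds.

This account concerns four small hydroxamic acids examined in an assay on isolated protein for inhibition of tyrosine-protein kinase CSK (Homo sapiens), tested at 25 uM, in the presence of a further agent that is not named here; on this read-out lower numbers stand for less inhibition and higher numbers for more inhibition at the one concentration tested (going by the name of the read-out). Compound 1, `N[C@@H](CCC(=O)NO)C(=O)O`, gives 0% in this assay. Compound 2, `CCCC(N)C(=O)NO`, gives 0% in this assay. Compound 3, `NCCC(=O)NO`, gives 0% in this assay, so it stands level with compound 1 and compound 2 at the digits reported, and the gaps between it and either of them lie within the usual scatter. None of the three measured compounds shows inhibition at the concentration tested. Compound 4, `NCC(=O)NO`, has not yet been measured. It differs from compound 3 by amino in place of aminomethyl on a saturated chain carbon bound to a carbonyl carbon. Among the compounds with values here, since every measured compound sits at the same flat value, there is no measured step to suggest a direction, and the step of no change at the digits printed from compound 3 to compound 4 (within the scatter) is expected to be none beyond the scatter. The estimate for compound 4 in this assay is therefore 0%, with a range from -8% to 10%.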

Compound 4, a percentage reported as inhibition, at one concentration (the size of the read-out at that concentration, not a potency): 0%
The estimate for compound 4 equals the measured number at the digits printed; the measured number falls inside the stated range.
By their numbers in this assay, from the lowest: compounds 1, 2, 3 and 4 (each within the scatter of the next).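

Within the data shown here, the first steps between compounds differing in one place can now be read in this assay: amino in place of aminomethyl on a saturated chain carbon bound to a carbonyl carbon gives no change at the digits printed from compound 3 to compound 4 (within the scatter). Hydrogen in place of propyl on a saturated chain carbon bound to an amine nitrogen and a carbonyl carbon gives no change at the digits printed from compound 2 to compound 4 (within the scatter), so neither change moves the read-out beyond the scatter, whether the chain is altered or its propyl group is lost. No supporting evidence bears on this flat result.

With every compound shown at the same flat value, these steps cannot tell whether either place has any influence on inhibition at the one concentration tested. From the compounds shown here alone, whether a phenyl ring or a chain longer than propyl on that saturated chain carbon would give measurable inhibition remains open.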